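A few compounds are considered here, and "the series" means these few. Any claim that something is new, unique, unknown or untested is made for them only; others in the source may bear on it.

Compound 1 `CC(=O)N1CCC(c2ccc(-c3cc(C(=O)O)cc4cc(-c5ccc(C(F)(F)F)cc5)ccc34)cc2)CC1` gives 100% in a functional assay on the whole organism (strain ICR) for inhibition, with Mus musculus as the target, with stated times of 7 days and 1 h, at a dose of 10 umol/kg by the intraperitoneal route (on this read-out higher numbers stand for more inhibition at the one dose given (going by the name of the read-out) and lower numbers for less inhibition), the higher of the two numbers measured. Compound 2 `O=C(O)c1cc(O)c2ccc(-c3ccc(C(F)(F)F)cc3)cc2c1` gives 64.2% in this assay, a gap beyond the usual scatter. Compound 3 `CCC(=O)N1CCC(c2ccc(-c3cc(C(=O)O)cc4cc(-c5ccc(C(F)(F)F)cc5)ccc34)cc2)CC1` is not yet measured; it differs from compound 1 by methyl in place of hydrogen on a saturated chain carbon bound to a carbonyl carbon. Among the compounds with values here, no step between measured compounds covers such a change, so its effect is unknown. The expected step is a number 7 percentage points lower from compound 1 to compound 3 (within the scatter), none beyond the scatter, because compound 1 already gives 100% at the top of the read-out. Compound 3 is expected to give 93%, within 72% to 100%.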

Compound 3, a percentage reported as inhibition, in the whole organism at one dose (the size of the read-out at that dose, not a potency): 77.2%
The estimate for compound 3 lay 15.8 percentage points above the measured number; low and high end bracket the measured number.
By their numbers in this assay, from the lowest: compound 2; then compound 3; then compound 1.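

Going from 1-acetylpiperidin-4-yl to 1-propanoylpiperidin-4-yl gives a number 22.8 percentage points lower from compound 1 to compound 3 (beyond the scatter) in this assay. A single methyl on a saturated chain carbon bound to a carbonyl carbon therefore changes the read-out at this dose, so this place is not indifferent to added carbon, at least for this one change. Nothing at hand accounts for the drop.

Open, on these data alone, is whether a longer chain such as butanoyl would lower the number further in this assay, or whether the drop is specific to propanoyl. Also open, as far as these compounds go, is how a formyl group or a terminal amine on this chain would read.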